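Chloro for methyl on the aryl ring: one repeated change

The source may report more compounds than this note shows. Statements on the series, on what has been measured and on what is new or still open speak of the compounds shown alone.

Working notes on a small set sharing one core, read in a functional assay on the whole organism with Mus musculus as the target, with a stated time of 1 h; on this read-out higher numbers stand for an effect only at larger amounts of compound and lower numbers for an effect already at smaller amounts. Going by the values given here, compound 1 `Cc1ccccc1-c1nnc(N(N)Cc2ccccc2)s1` is the first measured member; in this assay compound 1 gives 44 mg/kg. Compound 2 `NN(Cc1ccccc1)c1nnc(-c2ccccc2Cl)s1` differs from it by chloro in place of methyl on an aromatic carbon. In this assay compound 2 gives 143 mg/kg. The measured step is a 3.3-fold higher number from compound 1 to compound 2 (0.51 log units; beyond the scatter), so the chloro analogue needs a larger dose for the same effect.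

Compound 3 `CNN(C)c1nnc(-c2ccccc2C)s1` belongs to a second core; the difference between the two cores is not broken down here. In this assay compound 3 gives 23 mg/kg, a number within the scatter of the value for compound 1.

Compound 4 `CNN(C)c1nnc(-c2ccccc2Cl)s1` has not been measured. It differs from compound 3 by chloro in place of methyl on an aromatic carbon. This is the same kind of change as the one seen between the first two compounds, though the surroundings are described differently: in the first pair the chloro enters ortho to a large group, in the second pair ortho to a group of 9 heavy atoms.

The expectation for compound 4 rests on one earlier step only, so the estimate is expected to carry a wide range. A step of about a 3.0-fold higher number from compound 3 to compound 4 (0.48 log units; beyond the scatter) is expected because the same change gave a 3.3-fold higher number from compound 1 to compound 2 (0.51 log units; beyond the scatter) on the first core. For compound 4 the value in this assay is therefore estimated at 70 mg/kg, with an expected range from 30 mg/kg to 170 mg/kg.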

Compound 4, dose for half-maximal effect: 25 mg/kg
Compound 4: middle estimate off by 2.8-fold (0.45 log units), on the high side, outside the stated range (below it).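

In this assay, chloro in place of methyl on an aromatic carbon does not keep the size of its step from one core to the other: the same change on two cores in this assay, a 3.3-fold higher number (0.51 log units; beyond the scatter) from compound 1 to compound 2 and a 1.1-fold higher number (0.04 log units; within the scatter) from compound 3 to compound 4, 3.0-fold (0.48 log units) apart, beyond the scatter of two such steps

On the core of compound 3, the change gives a 1.1-fold higher number from compound 3 to compound 4 (0.04 log units; within the scatter), so this read-out does not separate the methyl and chloro analogues there, whereas the same change on the core of compound 1 gives a 3.3-fold higher number from compound 1 to compound 2 (0.51 log units; beyond the scatter). This shows that, in this series, a step read on one core is not a safe guide to the step on the other, but with a single pair per core it does not show why the two steps differ, nor which core is the more typical.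

The compounds shown leave open whether other groups on the same aromatic carbon, such as fluoro, methoxy or trifluoromethyl, would also give steps that depend on the core. They also leave open which part of the difference between the two cores goes with the gap between the steps, and whether a further core carrying an ethyl group or a longer chain would behave like the core of compound 1 or that of compound 3.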